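This account rests on a few compounds, and the source may have more. Where it says the series, first, only, none or still open, it means among the compounds named here.

Two compounds of the series have numbers in a functional assay on CHO cells for antagonist activity at Orexin/Hypocretin receptor type 1 (Homo sapiens), read by FLIPR and calcium flux; a higher number here means a weaker inhibitor, a lower number a stronger inhibitor. Compound 1 `CNC(=O)[C@@H](c1ccccc1)N1CCn2c(CC3CC3)nc(Cl)c2[C@@H]1CCc1ccc(C(F)(F)F)cc1` gives 1430 nM. Compound 2 `CCc1nc(I)c2n1CCN([C@@H](C(=O)NC)c1ccccc1)C2CCc1ccc(C(F)(F)F)cc1` gives 717 nM, the lower of the two numbers, with compound 1 as its nearest neighbour; that gap lies within the scatter, so no order between the two is claimed. Compound 3 `CCc1ncc2n1CCN([C@@H](C(=O)NC)c1ccccc1)C2CCc1ccc(C(F)(F)F)cc1` is not yet measured. It differs from compound 2 in one place: hydrogen in place of iodo on an aromatic carbon. Among the compounds with values here, no step between measured compounds covers this change. A moderate shift toward a higher number is expected, a 3.5-fold higher number from compound 2 to compound 3 (0.54 log units; beyond the scatter), somewhat beyond the scatter. Compound 3 is estimated at 2500 nM, within a range from 800 nM to 8000 nM.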

Compound 3, half-maximal inhibitory concentration: 10000 nM
The estimate for compound 3 lay 4.0-fold (0.60 log units) below the measured number, outside the stated range (above it).
By their numbers in this assay, from the lowest: compounds 2 and 1 (each within the scatter of the next); then compound 3.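

In this assay hydrogen in place of iodo gives a 14-fold higher number from compound 2 to compound 3 (1.14 log units; beyond the scatter) with the rest of the structure unchanged. Within the data shown here, this is the first reading of this aromatic carbon on its own, since compounds 1 and 2 differ in more than one place, and it shows that the number depends strongly on what this position carries. Nothing available here accounts for the size of the step. From the compounds shown here alone, whether iodo is specifically needed or other substituents would serve equally remains open. A bromo, methyl or nitrile group on this carbon would test that.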